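The source may hold more compounds than are shown below. What is called first, only, known or untested is meant among the compounds shown, and "the series" means these compounds.

Measured compounds: compound 1 `Cc1ccc(CCSc2nc3c(c(=O)n(C)c(=O)n3C)n2C)cc1`, 72 nM; compound 2 `Cn1c(=O)c2c(nc([S+]([O-])CCc3ccc(Br)cc3)n2C)n(C)c1=O`, 471 nM; compound 3 `Cn1c(=O)c2c(nc([S+]([O-])Cc3ccccc3)n2C)n(C)c1=O`, 131000 nM. All values are from an assay on microsomes for inhibition of Amine oxidase [flavin-containing] B (Homo sapiens), read by fluorescence and spectrophotometry, with a stated time of 20 min; on this read-out lower numbers stand for stronger inhibition and higher numbers for weaker inhibition.

Compound 1 gives the lowest number of the three in this assay; compound 2 stands nearest, compound 3 furthest. Compound 4 `Cn1c(=O)c2c(nc(SCCCc3ccc(Cl)cc3)n2C)n(C)c1=O` differs from compound 1 by 4-chlorobenzyl in place of 4-methylphenyl on a saturated chain carbon, two bonds along the chain from a sulfur. Among the measured compounds shown here, the one measured step that bears on this change is a 280-fold higher number from compound 2 to compound 3 (2.44 log units; beyond the scatter), which shows a large loss when the halogen-bearing benzyl group gives way to a shorter aryl group. For the measured compounds named here, the change to compound 4 runs the other way, keeping a halogen and lengthening the chain, though it also removes the methyl group; no measured pair isolates either part. Compound 4 is therefore expected to stay close to compound 1, estimated as a 1.2-fold lower number from compound 1 to compound 4 (0.08 log units; within the scatter). The estimate for compound 4 is 60 nM, within 15 nM to 250 nM.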

Compound 4, half-maximal inhibitory concentration in the Amine oxidase [flavin-containing] B assay: 61 nM
Compound 4: middle estimate off by 1.0-fold (0.01 log units), on the low side, and the stated range covers the measured number.
By their numbers in the Amine oxidase [flavin-containing] B assay, from the lowest: compounds 4 and 1 (each within the scatter of the next); then compound 2; then compound 3.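

In the Amine oxidase [flavin-containing] B assay the change to 4-chlorobenzyl at this saturated chain carbon gives a 1.2-fold lower number from compound 1 to compound 4 (0.07 log units; within the scatter), so compounds 1 and 4 stand level. This position therefore accepts 4-chlorobenzyl as readily as 4-methylphenyl, which the large step of a 280-fold higher number from compound 2 to compound 3 (2.44 log units; beyond the scatter) could not show. In a physicochemical assay for lipophilicity, using the shake flask method, measured as octanol-water partition (a lower number here means a more polar compound, a higher number a more lipophilic compound), the same change does register, as higher lipophilicity without a matching difference in inhibition: the measured partition coefficient of compound 1, 3.15, and of compound 4, 3.59, a number 0.44 log units higher (beyond the scatter). In the physicochemical assay compound 1 gives 3.15 and compound 4 gives 3.59.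

The chain extension and the exchange of methyl for chlorine arrive together, so neither can be read alone. As far as these compounds go, how an amine or a carboxylic acid in place of the chlorine would behave in either assay remains open.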